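The source may hold more compounds than are shown below. What is called first, only, known or untested is meant among the compounds shown, and "the series" means these compounds.

Compound 1 `C#CCNC(=O)C[C@H](NC(=O)c1ccc(C#Cc2ccccc2)cc1)C(=O)NO` in a physicochemical assay for lipophilicity (on this read-out higher numbers stand for higher lipophilicity and lower numbers for lower lipophilicity), gives 3. Among the compounds with values here, compound 2 `NC(=O)C[C@H](NC(=O)c1ccc(C#Cc2ccccc2)cc1)C(=O)NO` gives 1 in this assay, and the single measured step, a number 2.00 log units lower from compound 1 to compound 2 (beyond the scatter), concerns a substituent on an amide-type nitrogen. Compound 3 `CC(NC(=O)c1ccc(C#Cc2ccccc2)cc1)C(=O)NO` is reported in this assay only as a limit, > 3. That places it at the limit of > 3 in this assay, at which 1 of the 3 values shown sits. Compound 4 `CC(C)C(NC(=O)c1ccc(C#Cc2ccccc2)cc1)C(=O)NO` differs from compound 3 by isopropyl in place of methyl on a saturated chain carbon bound to an amide-type nitrogen and a carbonyl carbon. Within the data shown here, no measured step covers this place; the one known step is large but sits elsewhere, so its size is not transferred. Compound 4 is expected at 4, with a range from 3.4 to 4.6, and most likely reported again only as a limit. The expected step that the limit leaves unreadable from compound 3 to compound 4 is estimated as a modest rise.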

Compound 4, distribution coefficient: > 3
Compound 4: only a limit was reported; the forecaster's own chance of this, stated with the estimate: 85%; the middle value lies beyond the limit too.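

Like compound 3, compound 4 is reported in this assay only as a limit, > 3, so no step between the two can be read: the limit of > 3 in this assay, at which 2 of the 4 values shown sit.

The compounds shown leave open how far compound 3 and compound 4 lie past that limit, and whether they differ at all.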